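Extending the Fluorinated Tail of Compound 3

The source may report more compounds than this note shows. Statements on the series, on what has been measured and on what is new or still open speak of the compounds shown alone.

Three compounds share one core. Compound 1 `C[C@]1(c2ccc(O)cc2)CSc2cc(O)ccc2[C@H]1CCCCCCCC(CCCC(F)(F)C(F)(F)F)C(=O)O` has "not determined" (no result reported) in a functional assay on the whole organism for antagonist activity, with Mus musculus as the target, at a dose of 3 mg/kg by the oral route; a higher number here means a stronger effect of the compound at the dose given, a lower number a weaker effect. Compound 2 `C[C@]1(c2ccc(O)cc2)CSc2cc(O)ccc2[C@H]1CCCCCCCCCC(CCC(F)(F)C(F)(F)C(F)(F)C(F)(F)F)C(=O)O` gives 38% in this assay. Compound 3 `C[C@]1(c2ccc(O)cc2)CSc2cc(O)ccc2[C@H]1CCCCCCCCCC(CCCC(F)(F)C(F)(F)F)C(=O)O` gives 45% in this assay, and the two numbers lie within the usual scatter of each other, so neither stands apart. Compound 4 `C[C@]1(c2ccc(O)cc2)CSc2cc(O)ccc2[C@H]1CCCCCCCCCC(CCCC(F)(F)C(F)(F)C(F)(F)C(F)(F)F)C(=O)O` has not yet been measured. It differs from compound 3 in one place: 1,1,2,2,2-pentafluoroethyl in place of fluoro on a saturated chain carbon bound to two fluorine atoms and a saturated chain carbon. Among the compounds with values here, with only two numbers at hand, and those two indistinguishable, no direction can be read from the known compounds. The expected step from compound 3 to compound 4 is therefore a number 3 percentage points lower from compound 3 to compound 4 (within the scatter), small and within the scatter. Compound 4 is expected to reach about 42%, between 25% and 60%.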

Compound 4, a percentage reported as inhibition, in the whole organism at one dose (the size of the read-out at that dose, not a potency): 55%
Beside the measured number, compound 4's estimate is 13 percentage points below it, and the stated range covers the measured number.
By their numbers in this assay, from the lowest: compounds 2, 3 and 4 (each within the scatter of the next, the first and the last beyond it).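

At this place, on a saturated chain carbon bound to two fluorine atoms and a saturated chain carbon, 1,1,2,2,2-pentafluoroethyl can stand in for fluoro with the effect kept: in this assay the step is a number 10 percentage points higher from compound 3 to compound 4 (within the scatter). A clearly larger fluorinated chain end therefore costs nothing measurable here, though the step cannot be called a gain. Nothing at hand bears on why the number moved as it did.

Going by these compounds, whether a still longer fluorinated chain or an amine in this place would keep the effect stays open. So does whether the same holds at other doses.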